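The source may report more compounds than this note shows. Statements on the series, on what has been measured and on what is new or still open speak of the compounds shown alone.

Measured in a functional assay on HepG2 cells (Homo sapiens) for antiproliferative activity, read by MTT assay, with a stated time of 72 h; a higher number here means a weaker inhibitor, a lower number a stronger inhibitor:
Compound 1 `O=C1COc2ccc(-c3cnc(Cl)c(NS(=O)(=O)c4ccc(F)cc4)c3)cc2N1`: > 40000 nM
Compound 2 `O=C1COc2ccc(-c3cnc(Cl)c(NS(=O)(=O)c4ccc(F)cc4)c3)cc2N1c1ccccc1`: 35700 nM

The entry for compound 1, > 40000 nM, is a limit of the assay and not a number. Among the compounds with values here, compound 2 holds the only true number so far, 35700 nM, so it has no measured neighbour to be ranked against. The series already meets (the limit of > 40000 nM in this assay, at which 1 of the 2 values shown sits).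

Compound 3 `O=C1COc2ccc(-c3cnc(Cl)c(NS(=O)(=O)c4ccc(F)cc4)c3)cc2N1C1CC1` differs from compound 2 in one place: cyclopropyl in place of phenyl on an amide-type nitrogen in a ring. This puts cyclopropyl in place of phenyl on an amide-type nitrogen in a ring.

Within the data shown here, only one measured step bears on that nitrogen: an at least 1.1-fold lower number from compound 1 to compound 2 (0.04 log units; that floor lies within the scatter). That step put phenyl in place of hydrogen, and it shows no clear change, since its floor lies within the scatter. With that step so small and compound 2 at 35700 nM, no step beyond the scatter is expected in this assay. A result for compound 3 reported only as a limit would be no surprise. The expected step is a 1.0-fold higher number from compound 2 to compound 3 (0.00 log units; within the scatter). Compound 3 is estimated at 36000 nM, with an expected range of 15000 nM to 70000 nM.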

Compound 3, half-maximal inhibitory concentration: 8510 nM
Compound 3: middle estimate off by 4.2-fold (0.63 log units), on the high side; measured number outside the range, below it.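

In this assay, within the data shown here, this result shows for the first time that the group on the amide-type nitrogen can move the number: cyclopropyl in place of phenyl gives a 4.2-fold lower number from compound 2 to compound 3 (0.62 log units; beyond the scatter). Measured against the hydrogen at that position, cyclopropyl gives an at least 4.7-fold lower number from compound 1 to compound 3 (0.67 log units; beyond the scatter), whereas phenyl gave only an at least 1.1-fold lower number from compound 1 to compound 2 (0.04 log units; that floor lies within the scatter), so the identity of the group matters, and of the two groups shown only cyclopropyl produces a step clearly beyond the scatter. Both steps from compound 1 are only floors, and their true sizes stay unknown, because the entry for compound 1 is a limit and not a number: the limit of > 40000 nM in this assay, at which 1 of the 3 values shown sits.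

With only hydrogen, phenyl and cyclopropyl at this nitrogen, the compounds shown cannot separate the effect of having fewer carbon atoms from that of having a three-membered ring, a question that an open chain such as methyl or ethyl, or a larger ring such as cyclobutyl, could help settle. They also leave open whether an amine or a carboxylic acid carried on a longer chain at this nitrogen would lower the number further or raise it again.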